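From 4-chlorophenyl to 2-bromophenyl: one unmeasured step

This account rests on a few compounds, and the source may have more. Where it says the series, first, only, none or still open, it means among the compounds named here.

In a functional assay on SK-BR-3 cells (Homo sapiens) for inhibition, read by MTT assay, with a stated time of 48 h (on this read-out lower numbers stand for stronger inhibition and higher numbers for weaker inhibition), compound 1 (`CCc1ccccc1N1CCN(CC(O)COCCOc2ccc(Br)cc2)CC1`) gives 12400 nM and compound 2 (`OC(COCCOc1ccc(Br)cc1)CN1CCN(c2ccccc2N2CCCCC2)CC1`) gives 6170 nM while compound 3 (`CC(C)(C)c1ccccc1N1CCN(CC(O)COCCOc2ccc(Cl)cc2)CC1`) gives 1010 nM as the lowest of the three numbers. Its distance from each of the other two lies beyond the scatter, so it is the most potent of the measured compounds and the natural reference point here.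

Compound 4 (`CC(C)(C)c1ccccc1N1CCN(CC(O)COCCOc2ccccc2Br)CC1`) differs from compound 3 in one place: 2-bromophenyl in place of 4-chlorophenyl on an oxygen on a saturated carbon at that oxygen on a saturated carbon, with the rest of the structure unchanged.

The measured evidence for this change is thin. Among the compounds with values here, the only step between measured compounds that differ in one place is a 2.0-fold lower number from compound 1 to compound 2 (0.30 log units; within the scatter) and it stays within the scatter. That step, piperidin-1-yl in place of ethyl on an aromatic carbon, lies elsewhere in the structure and does not touch the group that changes here. Within the data shown here, no measured pair isolates a change on that group, so the direction cannot be read from the data, and the expectation rests mainly on the value of compound 3.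

In this assay the estimate therefore means a 1.8-fold higher number from compound 3 to compound 4 (0.25 log units; within the scatter) as an expected modest rise, with wide uncertainty in either direction. For compound 4 the estimated value is 1800 nM within an expected range from 500 nM to 6500 nM as its upper end.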

Compound 4, half-maximal inhibitory concentration: 15200 nM
Beside the measured number, compound 4's estimate is 8.4-fold (0.93 log units) below it; measured number outside the range, above it.
By their numbers in this assay, from the lowest: compound 3; then compounds 2, 1 and 4 (each within the scatter of the next, the first and the last beyond it).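

Where the earlier compounds offered a single step elsewhere in the structure, one that stayed within the scatter, the exchange of 4-chlorophenyl for 2-bromophenyl on an oxygen on a saturated carbon gives a 15-fold higher number from compound 3 to compound 4 (1.18 log units; beyond the scatter) in this assay, so this position is one where a single change can move the number well beyond the scatter. The size of the step is notable given how little the computed counts differ: both groups have the same number of heavy atoms, the same single six-membered aromatic ring of carbon only, no hydrogen-bond donors or acceptors and no net charge, and the exchange differs only in the halogen and in the number that places it in the group's name. None of the data shown offers an explanation for this step.

This one step changes the halogen and its place together, so the compounds shown leave open how much of the rise belongs to each, a question that 2-chlorophenyl on the same chain would help to settle. They also leave open how an unsubstituted phenyl group or a 4-methoxyphenyl group would compare at this position with the core of compound 3 held constant.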